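Aryl ether variation in the linked imine series

The compounds below may be only part of what the source reports. "The series", "measured", "known", "first", "only" and "open" are said of these compounds alone.

Compound 1 `Cc1ccc(Oc2c(/C=N\CCCCCOc3cc4oc(=O)cc(C)c4cc3Cl)c(C)nn2C)cc1` — in a functional assay on SMMC-7721 cells (Homo sapiens) for antiproliferative activity, read by MTT assay, with a stated time of 72 h (on this read-out lower numbers stand for stronger inhibition and higher numbers for weaker inhibition), compound 1 gives 11100 nM.
Compound 2 `Cc1nn(C)c(Oc2ccc(F)cc2)c1/C=N\CCCCCCOc1cc2oc(=O)cc(C)c2cc1Cl` — in this assay compound 2 gives 13500 nM.
Compound 3 `Cc1nn(C)c(Oc2ccc(Cl)cc2)c1/C=N\CCCCCCOc1cc2oc(=O)cc(C)c2cc1Cl` — in this assay compound 3 gives 2080 nM.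

Compound 3 stands lowest of the three numbers, with compound 1 and compound 2 both beyond the scatter above it. For the measured compounds named here, the only single-point step, a 6.5-fold lower number from compound 2 to compound 3 (0.81 log units; beyond the scatter), is modest. Compound 4 `Cc1nn(C)c(Oc2cccc(C(F)(F)F)c2)c1/C=N\CCCCCCOc1cc2oc(=O)cc(C)c2cc1Cl` carries 3-(trifluoromethyl)phenyl in place of 4-chlorophenyl on an oxygen on an aromatic ring. Going by the values given here, no measured step changes the kind and the place of the ring substituent at once; the step from compound 2 to compound 3 shows only that this substituent shifts the number. A step toward weaker inhibition, of uncertain size, is expected. Compound 4 is expected to give 4000 nM (range 1200 nM to 13000 nM), an expected step of a 1.9-fold higher number from compound 3 to compound 4 (0.28 log units; within the scatter).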

Compound 4, half-maximal inhibitory concentration: 24800 nM
The estimate for compound 4 lay 6.2-fold (0.79 log units) below the measured number, and the stated range ends below it.
By their numbers in this assay, from the lowest: compound 3; then compounds 1, 2 and 4 (each within the scatter of the next, the first and the last beyond it).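

In this assay, 3-(trifluoromethyl)phenyl in place of 4-chlorophenyl gives a 12-fold higher number from compound 3 to compound 4 (1.08 log units; beyond the scatter), so the low number of compound 3 does not carry over to this aryl ether. The other step, a 1.8-fold higher number from compound 2 to compound 4 (0.26 log units; within the scatter), stays within the scatter, so 4-fluorophenyl and 3-(trifluoromethyl)phenyl cannot be told apart here, while 4-chlorophenyl stands apart from both. No measured evidence bears on the origin of these steps. On these data alone, whether the kind of substituent or its place on the ring carries the large step stays open. As far as these compounds go, how a methoxy group or an amine on the same phenyl ring would read also stays open.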